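Cytotoxicity notes on compound 1 and compound 4

A few compounds are considered here, and "the series" means these few. Any claim that something is new, unique, unknown or untested is made for them only; others in the source may bear on it.

Among the measured compounds shown here, compound 1 `O=C(Nc1nc(-c2ccccc2)cs1)c1ccc([N+](=O)[O-])o1` is the only member of the series with a number in an ADME assay on Vero cells (Chlorocebus sabaeus) for cytotoxicity, read by MTT assay, with a stated time of 72 h (on this read-out lower numbers stand for stronger inhibition and higher numbers for weaker inhibition), where compound 1 gives 41700 nM. Compound 2 `CC(C)(C)OC(=O)Nc1cccc(-c2csc(NC(=O)c3ccc([N+](=O)[O-])o3)n2)c1` is entered in this assay as "not determined" (no result reported), and compound 3 `Nc1cccc(-c2csc(NC(=O)c3ccc([N+](=O)[O-])o3)n2)c1` is entered there as "not determined" (no result reported). Compound 4 `O=C(Nc1nc(-c2cccc(NS(=O)(=O)Cc3ccccc3)c2)cs1)c1ccc([N+](=O)[O-])o1` has not yet been measured there. Relative to compound 1 it differs as (benzylsulfonyl)amino in place of hydrogen on an aromatic carbon. For the measured compounds named here, no step between measured compounds exists to anchor the size of this change, so the expectation rests on compound 1 alone, whose 41700 nM sits at the weak end of the read-out. For compound 4 the step of a 1.4-fold lower number from compound 1 to compound 4 (0.14 log units; within the scatter) is expected to be modest, toward slightly stronger inhibition, without clearly leaving the scatter. Compound 4 is estimated at 30000 nM, with a range of 8000 nM to 100000 nM.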

Compound 4, half-maximal inhibitory concentration: 59300 nM
For compound 4 the middle estimate is 2.0-fold (0.30 log units) below the measured one; measured number inside the range.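

In this assay, among the compounds shown here, the first readable step is a 1.4-fold higher number from compound 1 to compound 4 (0.15 log units; within the scatter), so compound 4 cannot be told apart from compound 1. At this aromatic carbon, meta to a large group, (benzylsulfonyl)amino in place of hydrogen therefore produces no separation on this read-out, despite the 11 heavy atoms it adds. Nothing measured here offers a reason for this result.

Steps involving compound 2 and compound 3 cannot be read. As far as these compounds go, whether a carboxylic acid or a longer chain on this carbon would also stay within the scatter of compound 1 remains open.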